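This account rests on a few compounds, and the source may have more. Where it says the series, first, only, none or still open, it means among the compounds named here.

Working notes on the series in an assay on LtK cells with ATP-sensitive inward rectifier potassium channel 11 (Homo sapiens) as the target; on this read-out higher numbers stand for an effect only at larger amounts of compound and lower numbers for an effect already at smaller amounts.

Compound 1, `CC(=O)Nc1c(C(O)(C(F)(F)F)C(F)(F)F)ccc2ccccc12`, gives 18 nM in this assay. Within the data shown here, compound 2, `CC(C)CCC(=O)Nc1c(C(O)(C(F)(F)F)C(F)(F)F)ccc2ccccc12`, gives 49 nM in the same assay; the only measured step, a 2.7-fold higher number from compound 1 to compound 2 (0.43 log units; beyond the scatter), concerns growth of the chain on the carbonyl carbon. Among the measured compounds shown here, compound 2 thus carries the higher of the two numbers measured so far, and its only neighbour is compound 1.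

Compound 3, `O=C(Nc1c(C(O)(C(F)(F)F)C(F)(F)F)ccc2ccccc12)c1cccc(Cl)c1`, is the next entry. Its difference from compound 2: 3-chlorophenyl in place of isopentyl on a carbonyl carbon

The change again sits on the carbonyl carbon, so the step from compound 1 to compound 2 is the only one that bears on it, and that step was modest. No ring has yet been placed at this position, so the direction is uncertain. Swapping the chain for the aromatic group is expected to move the number at most modestly, a 1.2-fold lower number from compound 2 to compound 3 (0.09 log units; within the scatter). Compound 3 is therefore estimated at 40 nM, with a range from 12 nM to 150 nM.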

Compound 3, half-maximal effective concentration: 98 nM
Beside the measured number, compound 3's estimate is 2.5-fold (0.39 log units) below it, and the stated range covers the measured number.
By their numbers in this assay, from the lowest: compound 1; then compounds 2 and 3 (each within the scatter of the next).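

On the carbonyl carbon, the first ring at this position gives a 2.0-fold higher number from compound 2 to compound 3 (0.30 log units; within the scatter) in this assay, so these compounds do not separate 3-chlorophenyl from isopentyl. Measured against the methyl group of compound 1, the same ring gives a 5.4-fold higher number from compound 1 to compound 3 (0.74 log units; beyond the scatter), which makes 3-chlorophenyl the second group, after isopentyl, to carry a higher number than methyl beyond the scatter. Nothing at hand explains this response at the carbonyl carbon.

Open, going by these compounds, is how a plain phenyl, a pyridyl ring or an ethyl chain would read at this carbonyl carbon, and so whether the number follows the chlorine, the ring or the size of the group. Also open, on these data alone, is how a chain ending in an amine or a carboxylic acid would read there.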